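A few compounds are considered here, and "the series" means these few. Any claim that something is new, unique, unknown or untested is made for them only; others in the source may bear on it.

Measured in a physicochemical assay for solubility, in phosphate buffer, measured as kinetic solubility, at pH 7.4; a lower number here means a less soluble compound, a higher number a more soluble compound:
- compound 1 `Cc1ccc(C)c(-c2nc(CN3CCC(C(=O)NCCCN4C[C@H](C)C[C@H](C)C4)CC3)c(C)o2)c1`: 56.1 ug/mL
- compound 2 `Cc1ccccc1-c1nc(CN2CCC(C(=O)NCCCN3CCC(C)(C)CC3)CC2)c(C)o1`: > 69 ug/mL (a limit)
- compound 3 `Cc1oc(-c2ccc(Cl)cc2)nc1CN1CCC(C(=O)NCCCN2C[C@H](C)C[C@H](C)C2)CC1`: > 72 ug/mL (a limit)

Compound 2 has no numeric result in this assay, only the limit > 69 ug/mL. Within the data shown here, compound 3 also stands at a limit, so compound 1 holds the only true number in the set.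

Compound 4 `Cc1ccccc1-c1nc(CN2CCC(C(=O)NCCCN3CCCCC3)CC2)c(C)o1` has piperidin-1-yl in place of 4,4-dimethylpiperidin-1-yl on a saturated chain carbon, three bonds along the chain from an amide-type nitrogen.

Among the measured compounds shown here, the only measured step, an at least 1.2-fold higher number from compound 1 to compound 3 (0.10 log units; that floor lies within the scatter), puts 4-chlorophenyl in place of 2,5-dimethylphenyl at a different place, and it has a floor within the scatter. For the measured compounds named here, no measured step touches the group changed here, so it gives only weak guidance. The estimated step, an at least 1.0-fold lower number from compound 2 to compound 4 (0.01 log units; that floor lies within the scatter), is expected to stay within the scatter in this assay, with no direction favoured. A limit rather than a number is also a likely outcome. For compound 4 the expected value is 66 ug/mL, with an estimated range from 45 ug/mL to 80 ug/mL.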

Compound 4, solubility: > 65 ug/mL
Compound 4 gave a limit, no number (the forecaster's own chance of this, stated with the estimate: 65%); the middle value does not contradict the limit.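

In this assay, compound 2 and compound 4 both stand at limits, not numbers, so the step between them cannot be read. The compounds shown leave open whether piperidin-1-yl and 4,4-dimethylpiperidin-1-yl give any difference in solubility.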